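The source may report more compounds than this note shows. Statements on the series, on what has been measured and on what is new or still open speak of the compounds shown alone.

Working notes on the series in a functional assay on HL-60 cells (Homo sapiens) for cytotoxicity, read by WST assay, with a stated time of 48 h; a lower number here means a stronger inhibitor, a higher number a weaker inhibitor. Compound 1 `COc1cc(C(c2ccc(O)c(OC)c2)[C@H](C)[C@H](C)CO)ccc1O` gives only a limit: in this assay compound 1 returns > 100000 nM, which is a limit of the assay and not a number (the limit of > 100000 nM in this assay, at which 1 of the 3 values shown sits). Compound 2 `COC[C@@H](C)[C@@H](C)C(c1ccc(O)c(OC)c1)c1ccc(O)c(OC)c1` gives 85000 nM in this assay. Compound 3 `COc1cc(C(c2ccc(O)c(OC)c2)[C@H](CC(C)C)C(C)C)ccc1O` gives 9600 nM in this assay. The step of an at least 1.1-fold lower number from compound 1 to compound 2 (0.07 log units; that floor lies within the scatter) lies within the scatter. The steps of an at least 10-fold lower number from compound 1 to compound 3 (1.01 log units; beyond the scatter) and an 8.9-fold lower number from compound 2 to compound 3 (0.95 log units; beyond the scatter) both run in the same direction and both lie beyond the scatter.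

Compound 4 `COc1cc(C(c2ccc(O)c(OC)c2)[C@@H](CF)C(C)C)ccc1O` is not yet measured in this assay. It differs from compound 1 as follows: 1-(fluoromethyl)-2-methylpropyl in place of 2-(hydroxymethyl)-1-methylpropyl on a saturated chain carbon bound to two aromatic carbons. The two steps that bear on this change are those into compound 3, where the chain bearing the hydroxymethyl or methoxymethyl was exchanged for an alkyl chain; both lowered the number beyond the scatter. Compound 4 also drops the hydroxymethyl, but enters 1-(fluoromethyl)-2-methylpropyl rather than the larger 1-isopropyl-3-methylbutyl. A step in the same direction, smaller than an at least 10-fold lower number from compound 1 to compound 3 (1.01 log units; beyond the scatter), is therefore expected: an at least 2.8-fold lower number from compound 1 to compound 4 (0.45 log units; beyond the scatter). Compound 4 is expected to give 35000 nM, between 10000 nM and 100000 nM, with a fair chance that this assay again reports only a limit.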

Compound 4, half-maximal inhibitory concentration: 39000 nM
Estimate against measurement, compound 4: 1.1-fold (0.05 log units) below; the range from low to high includes it.
By their numbers in this assay, from the lowest: compound 3; then compound 4; then compound 2. At a limit, above all of these: compound 1.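

For the compounds shown here, compound 4 brings the first change at this place that keeps the size of the leaving chain, with the same heavy-atom count as 2-(hydroxymethyl)-1-methylpropyl and no hydrogen-bond donor or acceptor in the entering 1-(fluoromethyl)-2-methylpropyl; in this assay this gives an at least 2.5-fold lower number from compound 1 to compound 4 (0.40 log units; beyond the scatter), so a lower number at this place does not require the larger 1-isopropyl-3-methylbutyl. The same entering chain also gives a 2.2-fold lower number from compound 2 to compound 4 (0.34 log units; beyond the scatter), which shows that it does more here than the 2-(methoxymethyl)-1-methylpropyl chain, while a 4.1-fold higher number from compound 3 to compound 4 (0.61 log units; beyond the scatter) leaves 1-isopropyl-3-methylbutyl with the lowest number of the compounds at this place. Compound 1 remains a limit of the assay and not a number, so the step from it is only a floor: the limit of > 100000 nM in this assay, at which 1 of the 4 values shown sits.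

As far as these compounds go, compound 4 moves the branching and the stereocentres of the chain as well as replacing the oxygen with fluorine, so the share of each in the step stays open. A 1-(hydroxymethyl)-2-methylpropyl or 1-(aminomethyl)-2-methylpropyl chain at this place would separate the fluorine from the rearranged chain, and the opposite configuration of the 1-(fluoromethyl)-2-methylpropyl chain is also an open question.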